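The compounds below may be only part of what the source reports. "The series", "measured", "known", "first", "only" and "open" are said of these compounds alone.

Compound 1 `CCCC(CCC)C(=O)OCC1(CO)C/C(=C/c2ccncc2)C(=O)O1` gives 44 nM in an assay on cells for displacement of a labelled ligand from Ras guanyl-releasing protein 3 (Homo sapiens); on this read-out lower numbers stand for stronger inhibition and higher numbers for weaker inhibition.
Compound 2 `CCCC(CCC)C(=O)OCC1(CO)C/C(=C\c2cccnc2)C(=O)O1` gives 1.6 nM in this assay.
Compound 3 `CCCC(CCC)C(=O)OCC1(CO)C/C(=C\c2ccncc2)C(=O)O1` gives 13.8 nM in this assay.

Compound 2 stands at the lowest of the three numbers; the nearest is a step of an 8.6-fold higher number from compound 2 to compound 3 (0.94 log units; beyond the scatter) and the furthest lies an 8.6-fold higher number from compound 2 to compound 3 (0.94 log units; beyond the scatter) beyond that again, as compound 1 is a step of a 3.2-fold lower number from compound 1 to compound 3 (0.50 log units; beyond the scatter) further out. Compound 4 `CCCC(CCC)C(=O)OCC1(CO)C/C(=C/c2cccnc2)C(=O)O1` keeps every atom and bond of compound 2; the only difference is the two compounds have the same atoms and bonds; at least one stereo element is drawn with a configuration in one of them and without one in the other: 1 of 2 stereo elements differ; a double bond is drawn E in compound 2 and Z in compound 4. One measured step of the same kind exists, run in the opposite direction: a 3.2-fold lower number from compound 1 to compound 3 (0.50 log units; beyond the scatter), a pair distinguished solely by the fact that one of compounds 1 and 3 is drawn with a defined configuration and the other without, at the place where they differ. Reversing that change on compound 2 is therefore expected to raise the number by a modest step, a 3.1-fold higher number from compound 2 to compound 4 (0.49 log units; beyond the scatter). Compound 4 is estimated at 5 nM, with a range from 1.6 nM to 16 nM.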

Compound 4, inhibition constant: 670 nM
Beside the measured number, compound 4's estimate is 130-fold (2.13 log units) below it; the whole stated range lies below it.
By their numbers in this assay, from the lowest: compound 2; then compound 3; then compound 1; then compound 4.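

In this assay, turning the double bond from E to Z weighs far more with pyridin-3-yl on the chain, a 420-fold higher number from compound 2 to compound 4 (2.62 log units; beyond the scatter), than it does with pyridin-4-yl, so the size of this change depends on the ring carried. With the double bond drawn Z, pyridin-3-yl also gives the higher number, a 15-fold higher number from compound 1 to compound 4 (1.18 log units; beyond the scatter), whereas with E it gives the lower one. The ring swap therefore runs in opposite directions on the two double-bond forms: the same change on two cores in this assay, an 8.6-fold higher number (0.94 log units; beyond the scatter) from compound 2 to compound 3 and a 15-fold lower number (1.18 log units; beyond the scatter) from compound 4 to compound 1, 130-fold (2.12 log units) apart, beyond the scatter of two such steps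

Still open, as far as these compounds go, is whether a phenyl or pyrimidin-5-yl ring in place of the pyridine would behave the same way on each double-bond form.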